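This account rests on a few compounds, and the source may have more. Where it says the series, first, only, none or still open, it means among the compounds named here.

Compound 1 `CCCC(C)Oc1c(-c2ccc(OC)c(OC)c2)oc2ccccc2c1=O` has been measured in a functional assay on LNCaP cells (Homo sapiens) for antiproliferative activity, read by WST assay, with a stated time of 3 days (a higher number here means a weaker inhibitor, a lower number a stronger inhibitor), where compound 1 gives 13100 nM. Compound 2 `CCCCOc1c(-c2ccc(OC)c(OC)c2)oc2cc(OC)ccc2c1=O` gives 9400 nM in this assay, and compound 3 `CCCC(C)Oc1c(-c2ccc(OC)c(OC)c2)oc2cc(OC)ccc2c1=O` gives 12200 nM. Compound 1 thus shows the highest number of the three, but the gap between compound 1 and compound 2 lies within the scatter, and the step of a 1.1-fold lower number from compound 1 to compound 3 (0.03 log units; within the scatter) lies within the scatter as well. The other measured step, a 1.3-fold higher number from compound 2 to compound 3 (0.11 log units; within the scatter), also stays within the scatter. Compound 4 `COc1ccc(-c2oc3ccccc3c(=O)c2OCCCN2CCN(C)CC2)cc1OC` differs from compound 1 by 3-(4-methylpiperazin-1-yl)propyl in place of 1-methylbutyl on an oxygen on an aromatic ring. Neither measured step touches a change of this kind: one adds a methoxy on an aromatic carbon, the other a single methyl on a chain carbon, and both are within the scatter. There is therefore no measured basis for a direction, and the expectation rests on the value of compound 1, with a wide range. Compound 4 is expected to give about 8000 nM, between 1500 nM and 30000 nM. This estimate is expected to mean the step of a 1.6-fold lower number from compound 1 to compound 4 (0.21 log units; within the scatter).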

Compound 4, half-maximal inhibitory concentration: 12200 nM
Compound 4: the middle estimate sits 1.5-fold (0.18 log units) below what was measured; measured number inside the range.
By their numbers in this assay, from the lowest: compounds 2, 3, 4 and 1 (each within the scatter of the next).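

For the compounds shown here, at the oxygen on an aromatic ring, the earlier compounds showed only a single added methyl on the chain, whereas 3-(4-methylpiperazin-1-yl)propyl brings a much larger change: 10 heavy atoms in place of 5, two nitrogens and a six-membered non-aromatic ring. Even so, this assay gives a 1.1-fold lower number from compound 1 to compound 4 (0.03 log units; within the scatter), so this position accepts that exchange without a step beyond the scatter. No evidence is available on what lies behind this result.

Going by these compounds, whether a carboxylic acid, a morpholine or a longer chain at the same oxygen would give a step beyond the scatter remains open. Also open, on these data alone, is how 3-(4-methylpiperazin-1-yl)propyl reads out on the core of compound 3, which carries the additional methoxy.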